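This account rests on a few compounds, and the source may have more. Where it says the series, first, only, none or still open, it means among the compounds named here.

Measured compounds:
compound 1 `CC1CCN(c2cc(C(F)(F)F)ccc2CNC(=O)C(C)c2ccc(NS(C)(=O)=O)c(F)c2)CC1`, which in an assay on CHO cells for antagonist activity at transient receptor potential cation channel subfamily V member 1 (Homo sapiens), read by FLIPR (on this read-out lower numbers stand for stronger inhibition and higher numbers for weaker inhibition), gives 0.9 nM
compound 2 `CCCCCc1cc(C(F)(F)F)ccc1CNC(=O)C(C)c1ccc(NS(C)(=O)=O)c(F)c1`, which in this assay gives 0.4 nM

Among the measured compounds shown here, compound 2 gives the lowest of the two numbers so far; its only neighbour is compound 1, and the step of a 2.3-fold lower number from compound 1 to compound 2 (0.35 log units; beyond the scatter) is beyond the scatter. Compound 3 `CC(C(=O)NCc1ccc(C(F)(F)F)cc1-c1cccc(Cl)c1)c1ccc(NS(C)(=O)=O)c(F)c1` is not yet measured. It differs from compound 2 by 3-chlorophenyl in place of pentyl on an aromatic carbon. For the measured compounds named here, the one measured step, from compound 1 to compound 2, exchanged one saturated group for another at this same carbon and is modest in size; no measured pair exchanges a chain for an aromatic ring there, so no step bears directly on the change to compound 3. The step for compound 3 is therefore expected to be small, a 1.8-fold higher number from compound 2 to compound 3 (0.24 log units; within the scatter), in either direction or within the scatter. For compound 3 the estimate is 0.7 nM, with a range from 0.2 nM to 3 nM.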

Compound 3, inhibition constant: 1 nM
Beside the measured number, compound 3's estimate is 1.4-fold (0.15 log units) below it; the range from low to high includes it.
By their numbers in this assay, from the lowest: compound 2; then compounds 1 and 3 (each within the scatter of the next).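

In this assay, replacing the chain with an aromatic ring at this carbon gives a 2.5-fold higher number from compound 2 to compound 3 (0.40 log units; beyond the scatter), a modest change beyond the scatter, whereas replacing 4-methylpiperidin-1-yl with the same ring gives a 1.1-fold higher number from compound 1 to compound 3 (0.05 log units; within the scatter), which is within the scatter. The position therefore accommodates 3-chlorophenyl as well as it does 4-methylpiperidin-1-yl, and among these three groups only pentyl stands apart, with the lowest number. Nothing available explains why the chain gives a lower number than either ring-bearing group.

The compounds shown leave open whether the chlorine contributes anything, since an unsubstituted phenyl does not appear among them. They also do not show whether a chain longer than pentyl, a carboxylic acid or a primary amine would be tolerated at this carbon.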